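Swapping tert-butyl for cyclopropyl on a side chain

This account rests on a few compounds, and the source may have more. Where it says the series, first, only, none or still open, it means among the compounds named here.

Compound 1 `CC(C)(C)C[C@@H](O)C(=O)N1N=CC[C@H]1C(=O)NCc1cc(Cl)ccc1-n1cnnn1` gives 22 mL.min-1.g-1 
Compound 2 `CC(C)(C)C[C@@H](O)C(=O)N1C[C@@H]2C[C@@H]2[C@H]1C(=O)NCc1cc(Cl)ccc1-n1cnnn1` gives 20 mL.min-1.g-1 

Both numbers come from an ADME assay on liver for metabolic stability, with Liver microsome (Homo sapiens) as the target, read by LC-MS, using microsomes (a lower number here means slower removal, a higher number faster removal of the compound), and they lie within the usual scatter of each other, so compound 2 stands level with compound 1 on this evidence.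

Compound 3 (`O=C(NCc1cc(Cl)ccc1-n1cnnn1)[C@@H]1[C@H]2C[C@H]2CN1C(=O)[C@H](O)CC1CC1`) has not yet been measured. It differs from compound 2 in one place (cyclopropyl in place of tert-butyl on a saturated chain carbon, two bonds along the chain from a carbonyl carbon and an oxygen on a saturated carbon), with cyclopropyl in place of tert-butyl on a saturated chain carbon, two bonds along the chain from a carbonyl carbon and an oxygen on a saturated carbon.

Among the measured compounds shown here, no measured pair of compounds shows a change of this kind, so its size cannot be read from the data. A small move towards slower removal is expected in this assay and it may not go beyond the scatter. The estimated step of a 1.4-fold lower number from compound 2 to compound 3 (0.15 log units; within the scatter) is therefore modest. Compound 3 is expected to give 14 mL.min-1.g-1 (estimated range 7 mL.min-1.g-1 to 28 mL.min-1.g-1).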

Compound 3, intrinsic clearance in microsomes: < 14 mL.min-1.g-1
Compound 3 was reported as a limit (the forecaster's own chance of this, stated with the estimate: 5%); the middle value lies on the limit itself.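

Compounds 1 and 2 both carry tert-butyl at this saturated chain carbon, so they showed nothing about changing the group there. In this assay, cyclopropyl in place of tert-butyl gives an at least 1.4-fold lower number from compound 2 to compound 3 (0.15 log units; that floor lies within the scatter), which means that this change does not speed removal, while the smallest step it allows does not clear the usual scatter. Compound 3 is reported only as a limit, not as a number, so the full size of the step remains unknown: the limit of < 14 mL.min-1.g-1 in this assay, at which 1 of the 3 values shown sits.

From the compounds shown here alone, it remains open whether a larger step lies behind this limit, and whether cyclopropyl would act the same way on the core of compound 1. Going by these compounds, how a longer chain, an amine or a carboxylic acid would behave at this place also remains open.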